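A few compounds are considered here, and "the series" means these few. Any claim that something is new, unique, unknown or untested is made for them only; others in the source may bear on it.

Measured compounds:
- compound 1 `c1ccc2c(-c3nnc(-c4ccncc4)o3)c[nH]c2c1` — 10000 nM
- compound 2 `COc1ccc(-c2nnc(-c3c[nH]c4ccccc34)o2)c(OC)c1OC` — > 1000000 nM

Within the data shown here, compound 1 `c1ccc2c(-c3nnc(-c4ccncc4)o3)c[nH]c2c1` carries the only real number in a functional assay on LNCaP cells (Homo sapiens) for cytotoxicity, read by MTT assay (on this read-out lower numbers stand for stronger inhibition and higher numbers for weaker inhibition), where compound 1 gives 10000 nM. Compound 2 `COc1ccc(-c2nnc(-c3c[nH]c4ccccc34)o2)c(OC)c1OC` does not yield a number in this assay; for compound 2 the result is a limit, > 1000000 nM. So the one further value sits at the limit of > 1000000 nM in this assay, at which 1 of the 2 values shown sits, and compound 1 cannot be ranked against it beyond noting that compound 1 at least produced a number.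

Compound 3 `FC(F)(F)c1nnc(-c2c[nH]c3ccccc23)o1` has not yet been measured. It differs from compound 1 by trifluoromethyl in place of pyridin-4-yl on an aromatic carbon. Among the measured compounds shown here, no measured step between two compounds connects to this change, so there is nothing here to set its size. The step from compound 1 to compound 3 is estimated as a 3.0-fold higher number from compound 1 to compound 3 (0.48 log units; beyond the scatter), toward weaker inhibition. Compound 3 is expected to give about 30000 nM, with a range from 5000 nM to 300000 nM.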

Compound 3, half-maximal inhibitory concentration: > 1000000 nM
Compound 3: a limit, no number; the forecaster's own chance of this, stated with the estimate: 30%; at least 33-fold (1.52 log units) between middle value and limit.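

The result shows that the activity of compound 1 in this assay does not survive this exchange on the aromatic carbon: trifluoromethyl in place of pyridin-4-yl gives an at least 100-fold higher number from compound 1 to compound 3 (2.00 log units; beyond the scatter). Compound 3 gives only a limit, > 1000000 nM, not a number. The step therefore marks a minimum size, and compound 1, with pyridin-4-yl, is now the only compound shown to give a number, while the other two both end at the same limit: the limit of > 1000000 nM in this assay, at which 2 of the 3 values shown sit.

As far as these compounds go, the two limits cannot be ordered against each other, so how far compound 2 and compound 3 actually lie from compound 1 remains open. Also open, from the compounds shown here alone, is how a plain phenyl or an amine on this same carbon would read, and so whether anything beyond pyridin-4-yl gives a number here.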